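Formyl to Acetyl on the Shared Core

This account rests on a few compounds, and the source may have more. Where it says the series, first, only, none or still open, it means among the compounds named here.

Compound 2 `CC(Oc1ccccc1C=O)C1=NCCN1` carries a formyl group on an aromatic carbon of the shared core. Among the measured compounds shown here, in an assay on CHO cells for displacement of a labelled ligand from Alpha-2B adrenergic receptor (Homo sapiens) (on this read-out lower numbers stand for stronger inhibition and higher numbers for weaker inhibition), compound 2 gives 2090 nM, which stands at the top of the two numbers measured so far, although the step of a 1.6-fold higher number from compound 1 to compound 2 (0.20 log units; within the scatter) keeps it within the scatter of its only neighbour. That neighbour, compound 1 `CCOc1ccccc1OC(C)C1=NCCN1`, gives 1320 nM in this assay. Compound 3 `CC(=O)c1ccccc1OC(C)C1=NCCN1` has not yet been measured. The change from compound 2 to compound 3 is methyl in place of hydrogen on a carbonyl carbon; cut one bond further out, it reads formyl to acetyl. For the measured compounds named here, only one measured step bears on it, and only loosely: the exchange of ethoxy for formyl, a 1.6-fold higher number from compound 1 to compound 2 (0.20 log units; within the scatter), moved the number by less than the scatter. The expected step of a 1.0-fold lower number from compound 2 to compound 3 (0.02 log units; within the scatter) is therefore taken to lie within the scatter as well. Compound 3 is estimated at 2000 nM in this assay, with a range from 600 nM to 7000 nM.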

Compound 3, inhibition constant: 6170 nM
For compound 3 the middle estimate is 3.1-fold (0.49 log units) below the measured one; measured number inside the range.
By their numbers in this assay, from the lowest: compounds 1 and 2 (each within the scatter of the next); then compound 3.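

Among the compounds shown here, at this aromatic carbon, the carbonyl-bearing group is not indifferent to a small addition: methyl in place of hydrogen on the carbonyl carbon gives a 3.0-fold higher number from compound 2 to compound 3 (0.47 log units; beyond the scatter) in this assay and is the first step here to pass the scatter. Acetyl in place of ethoxy likewise gives a 4.7-fold higher number from compound 1 to compound 3 (0.67 log units; beyond the scatter) and so sets compound 3 apart from both earlier compounds, although formyl and ethoxy could not be told apart. No measurement bears on why a single added methyl has this effect.

The compounds shown leave open whether a longer chain on the carbonyl carbon, such as propanoyl, would carry the number further in the same direction. They also leave open where a carboxylic acid or a primary amide would stand at this aromatic carbon.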